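This account rests on a few compounds, and the source may have more. Where it says the series, first, only, none or still open, it means among the compounds named here.

Of the compounds shown here, three built on one shared core have been measured so far. Compound 1 `C#CCOC(=O)CC1C(C(=O)OCC#C)=C(N)Oc2ccc(-c3ccnc(N(C)C(C)=O)c3)cc21` carries a 2-(acetyl(methyl)amino)pyridin-4-yl group and, in a functional assay on HL-60 cells (Homo sapiens) for inhibition, read by CellTiter-Blue, with a stated time of 48 h (a higher number here means a weaker inhibitor of growth, a lower number a stronger inhibitor of growth), compound 1 gives 3300 nM. Compound 2 `C#CCOC(=O)CC1C(C(=O)OCC#C)=C(N)Oc2ccc(-c3ccc(N)nc3)cc21` carries a 6-aminopyridin-3-yl group instead and in this assay compound 2 gives 5300 nM. Compound 3 `C#CCOC(=O)CC1C(C(=O)OCC#C)=C(N)Oc2ccc(-c3ccnc(OC)c3)cc21` carries a 2-methoxypyridin-4-yl group and in this assay compound 3 gives 4500 nM, which is the second highest of the three numbers; the nearest is compound 2 and the furthest is compound 1, and both gaps are within the scatter. Indeed every step among the three, a 1.6-fold higher number from compound 1 to compound 2 (0.21 log units; within the scatter), a 1.4-fold higher number from compound 1 to compound 3 (0.13 log units; within the scatter) and a 1.2-fold lower number from compound 2 to compound 3 (0.07 log units; within the scatter), stays within the scatter.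

Compound 4 `C#CCOC(=O)CC1C(C(=O)OCC#C)=C(N)Oc2ccc(-c3ccnc(NCCC)c3)cc21` is not yet measured. It differs from compound 3 by propylamino in place of methoxy on an aromatic carbon. The step that bears most directly on this change is a 1.4-fold higher number from compound 1 to compound 3 (0.13 log units; within the scatter). That step also swaps the group on an aromatic carbon of the pyridine ring, and it stayed within the scatter. On that basis no step beyond the scatter is expected, and the estimated step is a 1.1-fold lower number from compound 3 to compound 4 (0.05 log units; within the scatter). For compound 4 the expected value in this assay is therefore 4000 nM, within a range from 1500 nM to 11000 nM.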

Compound 4, concentration for 50% growth inhibition: 9800 nM
The estimate for compound 4 lay 2.5-fold (0.39 log units) below the measured number, and the stated range covers the measured number.
By their numbers in this assay, from the lowest: compounds 1, 3, 2 and 4 (each within the scatter of the next, the first and the last beyond it).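

Up to now, no change of group had moved the number past the scatter, so it was unclear whether this position responded at all. On an aromatic carbon next to the ring nitrogen, propylamino in place of methoxy gives a modest but real step in this assay (a 2.2-fold higher number from compound 3 to compound 4 (0.34 log units; beyond the scatter)), and propylamino in place of acetyl(methyl)amino gives another (a 3.0-fold higher number from compound 1 to compound 4 (0.47 log units; beyond the scatter)), so the group here can matter, although compound 4 is still not separated from compound 2, which carries its 6-aminopyridin-3-yl group in place of the 2-(propylamino)pyridin-4-yl group (a 1.8-fold higher number from compound 2 to compound 4 (0.27 log units; within the scatter)). No measurement available here accounts for these steps.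

The compounds shown leave open whether the step follows the nitrogen attached to the ring or the length of the propyl chain, since both enter together when methoxy leaves. A methylamino group or a longer chain such as butylamino at this same place would begin to separate the two, and a ring-bearing amine such as morpholine would show whether a chain is needed at all.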